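Cytotoxicity notes: amino substituent variation, compound 4 pending

The source may report more compounds than this note shows. Statements on the series, on what has been measured and on what is new or still open speak of the compounds shown alone.

Measured so far in an ADME assay on A549 cells (Homo sapiens) for cytotoxicity, read by resazurin assay, with a stated time of 48 h; on this read-out higher numbers stand for lower toxicity in this test and lower numbers for higher toxicity in this test:
- compound 1 `CCCN(CCC)c1ccc(NC(=O)c2cc(Cl)ccc2O)c(Cl)c1` gives 10700 nM
- compound 2 `O=C(Nc1ccc(NCc2ccccc2)cc1Cl)c1cc(Cl)ccc1O` gives 19700 nM
- compound 3 `CC(C)(CCO)Nc1ccc(NC(=O)c2cc(Cl)ccc2O)c(Cl)c1` gives 170000 nM

Compound 1 stands at the lowest of the three numbers in this assay. Compound 2 lies nearest, at a 1.8-fold higher number from compound 1 to compound 2 (0.27 log units; within the scatter), and compound 3 lies furthest, at a 16-fold higher number from compound 1 to compound 3 (1.20 log units; beyond the scatter).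

Compound 4 `O=C(Nc1ccc(NCCCO)cc1Cl)c1cc(Cl)ccc1O` has not yet been measured in this assay. It differs from compound 1 in one place: (3-hydroxypropyl)amino in place of dipropylamino on an aromatic carbon.

Two of the measured steps bear on this change. Replacing dipropylamino by (3-hydroxy-1,1-dimethylpropyl)amino on the aromatic carbon gave a 16-fold higher number from compound 1 to compound 3 (1.20 log units; beyond the scatter), and replacing benzyl by 3-hydroxy-1,1-dimethylpropyl on the ring nitrogen gave an 8.6-fold higher number from compound 2 to compound 3 (0.94 log units; beyond the scatter). Both go the same way: a hydroxy-bearing alkylamino at this place has so far gone with a clearly higher number in this assay, meaning lower toxicity in this test. Going by the values given here, compound 4 carries a (3-hydroxypropyl)amino without the two methyls present in compound 3, so a step in the same direction is expected, though with only one such precedent its size is uncertain and may fall short of a 16-fold higher number from compound 1 to compound 3 (1.20 log units; beyond the scatter).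

For compound 4 the expected step is a 6.5-fold higher number from compound 1 to compound 4 (0.82 log units; beyond the scatter), giving an estimated 70000 nM with a range from 25000 nM to 200000 nM.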

Compound 4, half-maximal cytotoxic concentration: 106000 nM
Beside the measured number, compound 4's estimate is 1.5-fold (0.18 log units) below it; the range from low to high includes it.
By their numbers in this assay, from the lowest: compounds 1 and 2 (each within the scatter of the next); then compounds 4 and 3 (each within the scatter of the next).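

In this assay, the unbranched (3-hydroxypropyl)amino group gives a step in the same direction as the branched chain of compound 3, with a 9.9-fold higher number from compound 1 to compound 4 (1.00 log units; beyond the scatter) and a 5.4-fold higher number from compound 2 to compound 4 (0.73 log units; beyond the scatter). The two methyls of compound 3 are therefore not needed for a number in this range at this position, and a 1.6-fold lower number from compound 3 to compound 4 (0.21 log units; within the scatter) leaves no order to read between the two hydroxy-bearing chains. Nothing on hand gives a cause for these steps.

Going by these compounds alone, whether the hydroxy group itself matters remains open: a plain propylamino group at the same aromatic carbon would separate the terminal hydroxy from the change from dipropylamino to a single chain on the nitrogen, while compound 2 shows only that a benzylamino group with its nitrogen hydrogen does not produce a step beyond the scatter from compound 1. Going by these compounds, how far the effect extends along the chain is also open, as a shorter 2-hydroxyethylamino group, a longer 4-hydroxybutylamino group, or a chain ending in a carboxylic acid or an amine could each give a different number.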